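The compounds below may be only part of what the source reports. "The series", "measured", "known", "first", "only" and "open" are said of these compounds alone.

Values in a functional assay on KG-1 cells (Homo sapiens) for cytotoxicity, read by luminescence and CellTiter-Glo, with a stated time of 3 days (a higher number here means a weaker inhibitor, a lower number a stronger inhibitor), stand as follows
Compound 1 `N#Cc1ccc(NC(=O)c2cccc(Br)c2O)cc1` gives 3260 nM
Compound 2 `COc1cccc(C(=O)Nc2ccc(C#N)cc2)c1O` gives > 10000 nM, which is a limit and not a number
Compound 3 `O=C(Nc1ccc(OC(F)(F)F)c(Cl)c1)c1cc(Cl)ccc1O` gives 460 nM

Compound 2 stands at the limit of > 10000 nM in this assay, at which 1 of the 3 values shown sits. Compound 4 `N#Cc1ccc(NC(=O)c2cccc(F)c2O)cc1` has fluoro in place of methoxy on an aromatic carbon, ortho to a hydroxy group (fluoro in place of methoxy on an aromatic carbon). Among the measured compounds shown here, the one measured step that bears on this change is an at least 3.0-fold higher number from compound 1 to compound 2 (0.48 log units; beyond the scatter), with methoxy in place of bromo on an aromatic carbon, and it lies beyond the scatter. Removing the methoxy is therefore expected to move the number back towards compound 1 at 3260 nM, though fluoro is not bromo. The expected change is an at least 1.6-fold lower number from compound 2 to compound 4 (0.22 log units; that floor lies within the scatter), a modest step towards a lower number. Compound 4 is estimated at 6000 nM, within an expected range of 2500 nM to 14000 nM.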

Compound 4, half-maximal inhibitory concentration: 9690 nM
Compound 4: the middle estimate sits 1.6-fold (0.21 log units) below what was measured, within the range that was stated.
By their numbers in this assay, from the lowest: compound 3; then compound 1; then compound 4. At a limit, above all of these: compound 2.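

In this assay, fluoro in place of bromo, on the aromatic carbon ortho to a hydroxy group, gives a 3.0-fold higher number from compound 1 to compound 4 (0.47 log units; beyond the scatter), so the weakening earlier seen with methoxy also appears with fluoro. Fluoro in place of methoxy gives an at least 1.0-fold lower number from compound 2 to compound 4 (0.01 log units; that floor lies within the scatter), so no gain over methoxy can be claimed. Compound 2 holds a limit and not a number, which leaves that step open-ended: the limit of > 10000 nM in this assay, at which 1 of the 4 values shown sits.

From the compounds shown here alone, whether an amine or a methyl group at this position would match compound 1 stays open. So does whether these steps carry over to the core of compound 3.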